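The source may report more compounds than this note shows. Statements on the series, on what has been measured and on what is new or still open speak of the compounds shown alone.

Measured compounds:
Compound 2, `CCOC(=O)[C@@H]1CCCN(S(=O)(=O)c2ccc(S(=O)(=O)N3CCCCC3)cc2)C1`, in a functional assay on MIA PaCa-2 cells (Homo sapiens) for inhibition, read by MTT assay, with a stated time of 3 days; on this read-out higher numbers stand for weaker inhibition and lower numbers for stronger inhibition: > 10000 nM
Compound 1, `CCOC(=O)C1CCCCN1S(=O)(=O)c1ccc(S(=O)(=O)N(CC)CC)cc1`, in this assay: > 10000 nM

Neither of these values is a measured number. For compound 2 the value in this assay is a limit of the assay, meaning the compound showed no measurable inhibition up to that concentration. For compound 1 the value is likewise only a limit. Where compound 2 stands is therefore described entirely by the limit of > 10000 nM in this assay, at which 2 of the 2 values shown sit, and no real difference between the two compounds can be read from these figures.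

Compound 3, `CCOC(=O)[C@@H]1CCCN(S(=O)(=O)c2ccc(C(=O)N(CC)CC)cc2)C1`, differs from compound 2 in one place: diethylcarbamoyl in place of (piperidin-1-yl)sulfonyl on an aromatic carbon. Within the data shown here, no measured pair of compounds carries this particular change, so there is no step whose size could be used as a guide. Since compound 2 itself gives only a limit in this assay, the size of the step cannot be anchored at all, and the step from compound 2 to compound 3 is expected to be small, a step that the limit leaves unreadable from compound 2 to compound 3. Compound 3 is thus expected to remain weak in this assay, at an estimated 15000 nM, with a range from 4000 nM to 60000 nM.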

Compound 3, half-maximal inhibitory concentration: > 10000 nM
Compound 3 ended at the assay's limit (the forecaster's own chance of this, stated with the estimate: 70%); the middle value is on the limit's open side.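

In this assay, among these compounds, no step from compound 2 to compound 3 can be read, since both compounds give only a limit and not a number: the limit of > 10000 nM in this assay, at which 3 of the 3 values shown sit. On these data alone, whether diethylcarbamoyl in place of (piperidin-1-yl)sulfonyl changes inhibition at all stays open, and this assay gives no actual number for compound 1, compound 2 or compound 3.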